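From Fluoro to Methoxy on a Shared Aromatic Core

The compounds below may be only part of what the source reports. "The series", "measured", "known", "first", "only" and "open" are said of these compounds alone.

Compound 1: `Nc1ccc2c(c1)S(=O)(=O)NC(NC1CCC1)=N2`, 31000 nM
Compound 2: `O=S1(=O)NC(NC2CCC2)=Nc2ccc(F)cc21`, 356 nM

Of the compounds shown here, two sharing one core have been measured in a functional assay for inhibition of sulfonylurea receptor 1, Kir6.2 (Homo sapiens); on this read-out lower numbers stand for an effect already at smaller amounts and higher numbers for an effect only at larger amounts of compound. Compound 1 carries an amino group on an aromatic carbon and gives 31000 nM. Within the data shown here, compound 2, with fluoro on that aromatic carbon, gives 356 nM, the lowest of the two numbers; its nearest neighbour is compound 1, and the single recorded step is an 87-fold lower number from compound 1 to compound 2 (1.94 log units; beyond the scatter).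

Compound 3, `COc1ccc2c(c1)S(=O)(=O)NC(NC1CCC1)=N2`, differs from compound 2 by methoxy in place of fluoro on an aromatic carbon. Among the measured compounds shown here, no measured step involves a methoxy group, so the one step that bears on this change is the exchange on the same aromatic carbon, a large one toward a lower number. A methoxy group is neither of the two groups already compared, and the data give no way to place it nearer to one than to the other. Compound 3 is therefore expected to fall between the two measured values, and the expected step is a 4.2-fold higher number from compound 2 to compound 3 (0.62 log units; beyond the scatter). Compound 3 is estimated at 1500 nM, with a range from 300 nM to 8000 nM.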

Compound 3, half-maximal effective concentration: 3870 nM
The estimate for compound 3 lay 2.6-fold (0.41 log units) below the measured number, within the range that was stated.
By their numbers in this assay, from the lowest: compound 2; then compound 3; then compound 1.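

In this assay the same aromatic carbon of the shared core now carries three different groups, and methoxy does not match either of the other two: there is an 11-fold higher number from compound 2 to compound 3 (1.04 log units; beyond the scatter) and also an 8.0-fold lower number from compound 1 to compound 3 (0.90 log units; beyond the scatter) in this series. Both steps are beyond the scatter, so this position separates the three groups into an order, with fluoro giving the lowest number, methoxy an intermediate one and amino the highest, rather than a simple contrast between fluoro and amino. The exchange of fluoro for methoxy adds a heavy atom and a hydrogen-bond acceptor, but no measurement on these compounds explains the order of the three groups.

The compounds shown leave open where other groups on this aromatic carbon would fall in that order, for example chloro, hydroxy or the longer ethoxy chain. They also leave open whether the same order would hold if the cyclobutyl group on the shared core were replaced by another ring or by an open chain.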